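Benzimidazole amide piperazines: the arylpiperazine substituent

This account rests on a few compounds, and the source may have more. Where it says the series, first, only, none or still open, it means among the compounds named here.

Measured so far:
- compound 1 `O=C(CN1CCN(c2ccccc2)CC1)Nc1nc2ccccc2[nH]1`: 4.62%
- compound 2 `O=C(CN1CCN(c2ccccc2F)CC1)Nc1nc2ccccc2[nH]1`: 11.6%
- compound 3 `O=C(CN1CCN(c2ccccn2)CC1)Nc1nc2ccccc2[nH]1`: 30.8%

In a functional assay, read by spectrophotometry, with a stated time of 30 min, tested at 5 ug/mL (a higher number here means a stronger effect of the compound at the concentration tested, a lower number a weaker effect), compound 3 gives 30.8%, the highest of the three numbers; its steps to the other two, a number 19.2 percentage points higher from compound 2 to compound 3 (beyond the scatter) and a number 26.2 percentage points higher from compound 1 to compound 3 (beyond the scatter), both lie beyond the scatter. Between compound 1 and compound 2 the step of a number 7 percentage points higher from compound 1 to compound 2 (within the scatter) is within the scatter, so those two cannot be ordered.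

Compound 4 `COc1ccc(N2CCN(CC(=O)Nc3nc4ccccc4[nH]3)CC2)cc1` is not yet measured. It differs from compound 3 in one place: 4-methoxyphenyl in place of pyridin-2-yl on an amine nitrogen in a ring. The measured steps that bear on this change are the two that swap the group on the ring nitrogen, a number 26.2 percentage points higher from compound 1 to compound 3 (beyond the scatter) and a number 19.2 percentage points higher from compound 2 to compound 3 (beyond the scatter): both move away from a carbon-only ring to pyridin-2-yl and both raise the read-out modestly. Compound 4 goes the other way, back to a carbon-only ring, now carrying a methoxy group for which no comparison exists. A decrease in this assay is therefore expected for compound 4, of about the size seen on entering pyridin-2-yl, as a number 18.8 percentage points lower from compound 3 to compound 4 (beyond the scatter). With the methoxy group untested, the range is kept wide. Compound 4 is estimated at 12%, between 2% and 28%.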

Compound 4, a percentage reported as activity, at one concentration (the size of the read-out at that concentration, not a potency): 7.24%
The estimate for compound 4 lay 4.8 percentage points above the measured number; measured number inside the range.
By their numbers in this assay, from the lowest: compounds 1, 4 and 2 (each within the scatter of the next); then compound 3.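

In this assay, among these compounds, a number 23.6 percentage points lower from compound 3 to compound 4 (beyond the scatter) sets pyridin-2-yl apart from a third carbon-only ring, and this ring now carries a substituent, which the earlier comparisons did not cover. The substituents tested so far do not close that gap: a number 2.6 percentage points higher from compound 1 to compound 4 (within the scatter) and a number 4.4 percentage points lower from compound 2 to compound 4 (within the scatter) both lie within the scatter, so 4-methoxyphenyl, 2-fluorophenyl and unsubstituted phenyl on the amine nitrogen cannot be ordered. The leaving and entering groups have the same hydrogen-bond acceptor count, so that count does not separate compound 3 from compound 4, and no measurement is available to explain the difference.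

The compounds shown leave open whether the higher read-out depends on the ring nitrogen of pyridin-2-yl in that exact arrangement or extends to other nitrogen-containing rings, a question that pyridin-3-yl, pyridin-4-yl or pyrimidin-2-yl on the same amine nitrogen would address. They also leave open whether an aromatic ring is needed there at all, which a cyclohexyl group in its place would test, and whether a carboxylic acid or a nitrile on the phenyl ring would lift the read-out.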